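The source may report more compounds than this note shows. Statements on the series, on what has been measured and on what is new or still open speak of the compounds shown alone.

The compounds measured so far, each with its result in a functional assay on A549 cells (Homo sapiens) for antiproliferative activity, read by MTT assay, with a stated time of 72 h; a lower number here means a stronger inhibitor, a higher number a weaker inhibitor:

Compound 1, `O=[N+]([O-])c1ccc(COc2ccc(Nc3ncnc4cc5c(cc34)OCCOCCO5)cc2)cc1`, gives 8620 nM.
Compound 2, `FC(F)(F)c1ccc(COc2cccc(Nc3ncnc4cc5c(cc34)OCCOCCO5)c2)cc1`, gives only a limit of the assay, > 100000 nM.
Compound 3, `FC(F)(F)c1ccc(COc2cccc(Nc3ncnc4cc5c(cc34)OCCOCCOCCO5)c2)cc1`, gives 24900 nM.

Compound 3 stands at the highest of the two values that are actual numbers; the nearest is compound 1, whose number is lower by a gap beyond the usual scatter of repeated measurements. The result for compound 2 is a limit and nothing more, as is seen in the limit of > 100000 nM in this assay, at which 1 of the 3 values shown sits.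

Compound 4, `c1ccc(COc2cccc(Nc3ncnc4cc5c(cc34)OCCOCCOCCO5)c2)cc1`, has not yet been measured. It differs from compound 3 in one place: hydrogen in place of trifluoromethyl on an aromatic carbon. Among the measured compounds shown here, no pair of measured compounds differs by exactly this change, so its effect cannot be read off from the data at hand. The estimate therefore leans on compound 3, which gives 24900 nM, and allows room in both directions.

Compound 4 is expected to give about 30000 nM in this assay, most likely between 8000 nM and 100000 nM. The expected step is a 1.2-fold higher number from compound 3 to compound 4 (0.08 log units; within the scatter), which is not clearly beyond the scatter in either direction.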

Compound 4, half-maximal inhibitory concentration: > 100000 nM
Compound 4: no number, only a limit; the forecaster's own chance of this, stated with the estimate: 25%; middle value at least 3.3-fold (0.52 log units) from the limit.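

In this assay compound 4 gives > 100000 nM, which is a limit of the assay and not a number. Among the compounds shown here, the change from 4-(trifluoromethyl)benzyl to benzyl gives an at least 4.0-fold higher number from compound 3 to compound 4 (0.60 log units; beyond the scatter), so on this scaffold the trifluoromethyl group cannot simply be dropped without a loss of activity, something no earlier pair could show. The true size of that loss stays unknown, and only its lower bound can be read: the limit of > 100000 nM in this assay, at which 2 of the 4 values shown sit.

As far as these compounds go, with only trifluoromethyl and hydrogen compared at this place, it remains open whether a chlorine atom or a methoxy group would match compound 3, lose activity as compound 4 does, or improve on both. From the compounds shown here alone, it also remains open how the same change behaves on the core of compound 2, whose result is likewise only a limit.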